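Methyl for Fluoro on the Aryl Ring of Compound 1

The source may report more compounds than this note shows. Statements on the series, on what has been measured and on what is new or still open speak of the compounds shown alone.

Compound 1, `Cc1nnc(SCC(=O)N/N=c2/scc(-c3ccc(F)cc3)n2-c2ccccc2)s1`: 27.3 ug/mL
Compound 2, `O=C(CSc1ncccn1)N/N=c1/scc(-c2ccc(F)cc2)n1-c1ccccc1`: 110 ug/mL

In a functional assay on C6 cells (Rattus norvegicus) for cytotoxicity, read by MTT assay, with a stated time of 24 h (a lower number here means a stronger inhibitor, a higher number a weaker inhibitor), compound 1 gives the lowest of the two numbers. Among the measured compounds shown here, the only measured step, a 4.0-fold higher number from compound 1 to compound 2 (0.61 log units; beyond the scatter), changes the group on the sulfur and leaves the rest of the shared core untouched. Compound 3, `Cc1ccc(-c2cs/c(=N/NC(=O)CSc3nnc(C)s3)n2-c2ccccc2)cc1`, differs from compound 1 at another place: methyl in place of fluoro on an aromatic carbon. For the measured compounds named here, no measured step touches this position, so the data give no ground for a move in either direction. Compound 3 is therefore expected to stay close to compound 1, with an estimated step of a 1.1-fold higher number from compound 1 to compound 3 (0.04 log units; within the scatter). The estimate for compound 3 is 30 ug/mL, within 12 ug/mL to 75 ug/mL.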

Compound 3, half-maximal inhibitory concentration: 25.3 ug/mL
For compound 3 the middle estimate is 1.2-fold (0.07 log units) above the measured one; the measured number falls inside the stated range.
By their numbers in this assay, from the lowest: compounds 3 and 1 (each within the scatter of the next); then compound 2.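

In this assay, among the compounds shown here, the exchange of 4-fluorophenyl for 4-methylphenyl gives a 1.1-fold lower number from compound 1 to compound 3 (0.03 log units; within the scatter) and so provides the first reading at this position, which the earlier step left untouched. Here, methyl and fluoro on the aromatic carbon cannot be told apart. No available evidence explains this result.

The compounds shown leave open whether an amine or a carboxylic acid at this position would also stay within the scatter of compound 1. They also leave open whether the same exchange would read alike with pyrimidin-2-yl on the sulfur.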